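A few compounds are considered here, and "the series" means these few. Any claim that something is new, unique, unknown or untested is made for them only; others in the source may bear on it.

Working notes on the step from compound 2 (`COc1ccc(SCc2ccc(C(=O)Nc3ccccc3N)cc2)cc1`) to compound 4 (`Nc1ccccc1NC(=O)c1ccc(CSc2ccc(F)cc2)cc1`). In a functional assay on A-375 cells (Homo sapiens) for inhibition, read by CCK-8 assay, with a stated time of 72 h, tested at 2 uM (on this read-out higher numbers stand for more inhibition of growth at the one concentration tested and lower numbers for less inhibition of growth), compound 2 gives 10.2% and stands within the scatter of both other measured compounds. Compound 1 (`Cc1cc(C)cc(SCc2ccc(/C=C/C(=O)Nc3ccccc3N)cc2)c1`) gives 8.78% in the same read-out, and compound 3 (`COc1ccc(SCc2ccc(C(=O)Nc3ccccc3N)cc2)cc1OC`) gives 18.1% there.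

The change is fluoro in place of methoxy on an aromatic carbon, para to a large group. Among the compounds with values here, no measured step makes this exchange. The nearest evidence is the step of a number 7.9 percentage points higher from compound 2 to compound 3 (within the scatter) for methoxy in place of hydrogen on an aromatic carbon, which stays within the scatter. That single step is a different exchange and offers only a weak guide, so no step beyond the scatter is expected, in either direction.

The expected change is a number 1.2 percentage points lower from compound 2 to compound 4 (within the scatter) and this estimate stays within the scatter. Compound 4 is expected at 9% in this assay (estimated range 1% to 20%).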

Compound 4, percent growth inhibition at one concentration: 19.4%
Beside the measured number, compound 4's estimate is 10.4 percentage points below it, and the stated range covers the measured number.
By their numbers in this assay, from the lowest: compounds 1, 2, 3 and 4 (each within the scatter of the next, the first and the last beyond it).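

In this assay, within the data shown here, going from 4-methoxyphenyl to 4-fluorophenyl gives a number 9.2 percentage points higher from compound 2 to compound 4 (within the scatter), the only direct reading so far of a replacement of the methoxy at this place, para to a large group. Beside a number 7.9 percentage points higher from compound 2 to compound 3 (within the scatter), it makes two changes on this ring, and neither takes the read-out beyond the scatter, so the methoxy of compound 2 is not shown to be needed at this place. The data shown offer no measurement that could account for the size of this step.

From the compounds shown here alone, how an amine, a carboxylic acid or a longer chain at this place would read stays open. Going by these compounds, with a single concentration as the only read-out, it also stays open whether compound 2 and compound 4 differ at all.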